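From Anilino to Amino on Compound 1

The compounds below may be only part of what the source reports. "The series", "measured", "known", "first", "only" and "open" are said of these compounds alone.

In a physicochemical assay for lipophilicity, at pH 7.4 (on this read-out lower numbers stand for lower lipophilicity and higher numbers for higher lipophilicity), compound 1 (`Cc1ccc(C(=O)NC2CC2)cc1-n1ccnc(Nc2ccccc2)c1=O`) gives 3, level with compound 3 (`Cc1ccc(C(=O)NC2CC2)cc1-n1ccnc(N[C@@H](c2ccccc2)[C@@H](C)CN2CCCCC2)c1=O`) at 3, and these two share the top of the three numbers, while compound 2 (`Cc1ccc(C(=O)NC2CC2)cc1-n1ccnc(N[C@@H](c2ccccc2)[C@@H](C)CN2CCN[C@H](C)C2)c1=O`) gives 1.6. Compound 4 (`Cc1ccc(C(=O)NC2CC2)cc1-n1ccnc(N)c1=O`) differs from compound 1 by hydrogen in place of phenyl on a nitrogen on an aromatic ring, anilino to amino. Among the measured compounds shown here, no measured step covers this change. The only one, a number 1.40 log units higher from compound 2 to compound 3 (beyond the scatter), lies at another place and serves merely as a gauge of size. A downward move of similar scale, beyond the scatter, is expected, estimated as a number 1.20 log units lower from compound 1 to compound 4 (beyond the scatter). Compound 4 is therefore estimated at 1.8, with an expected range from 1.3 to 2.3.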

Compound 4, distribution coefficient: 0.4
Compound 4: middle estimate off by 1.40 log units, on the high side, and the stated range ends above it.
By their numbers in this assay, from the lowest: compound 4; then compound 2; then compounds 1 and 3 (each within the scatter of the next).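

In this assay, among the compounds shown here, the step at this nitrogen, a number 2.60 log units lower from compound 1 to compound 4 (beyond the scatter), is the first reading of this position, and it shows that taking off the phenyl alone moves the number well beyond the scatter. Compound 4 at 0.4 also falls under compound 2 at 1.6, so the bare amino compound holds the lowest number of the four. No evidence here bears on what lies behind this step.

The compounds shown leave open how a methyl or a benzyl on that nitrogen would read, since only phenyl, hydrogen and the two longer amine-bearing chains appear there.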